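The source may report more compounds than this note shows. Statements on the series, on what has been measured and on what is new or still open speak of the compounds shown alone.

Compound 1 `CCN(CC)c1ccc2nc(-c3cccc4ccccc34)[nH]c(=O)c2c1` and compound 2 `Cc1ccc2nc(-c3ccccc3N(C)C)[nH]c(=O)c2c1` have both been tested in an assay on isolated protein for inhibition of DNA topoisomerase 1 (Homo sapiens), with a stated time of 30 min, tested at 20 uM; a higher number here means a stronger effect of the compound at the concentration tested, a lower number a weaker effect. Compound 1 gives 25.5%, and compound 2 gives 21.1%; these two numbers lie within the usual scatter of each other, so neither compound can be said to act more strongly than the other. Compound 3 `CN(C)c1ccc2nc(-c3cccc4ccccc34)[nH]c(=O)c2c1` has not yet been measured. It differs from compound 1 in one place: dimethylamino in place of diethylamino on an aromatic carbon. Within the data shown here, no measured pair shows what this change does here, so no step beyond the scatter is expected in this assay. Compound 3 is therefore estimated at 23%, with a range from 10% to 38%. The expected step of a number 2.5 percentage points lower from compound 1 to compound 3 (within the scatter) is small.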

Compound 3, a percentage reported as inhibition, at one concentration (the size of the read-out at that concentration, not a potency): 2.4%
For compound 3 the middle estimate is 20.6 percentage points above the measured one; the whole stated range lies above it.
By their numbers in this assay, from the lowest: compound 3; then compounds 2 and 1 (each within the scatter of the next).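

In this assay dimethylamino in place of diethylamino on an aromatic carbon brings a number 23.1 percentage points lower from compound 1 to compound 3 (beyond the scatter) and so shows that this place on the shared core responds to a change in the chains on the amine alone. Both groups have the same count of hydrogen-bond donors and acceptors, so that count does not separate them. Nothing measured here explains the step.

Still open, from the compounds shown here alone, is how dipropylamino, with its longer chains, or a plain amino group would read out at this place. Going by these compounds, whether the same change does the same on another core also remains open.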